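Swapping chloro for hydroxymethyltriazolyl on a cembranoid enone

This account rests on a few compounds, and the source may have more. Where it says the series, first, only, none or still open, it means among the compounds named here.

Compound 2 `CC(C)=CCC[C@]1(C)/C=C/[C@@H](OC(=O)C=C(C)C)[C@](C)(O)/C=C/C(=O)/C(CCl)=C\C1` gives 150 nM in a functional assay on A549 cells (Homo sapiens) for antiproliferative activity, read by MTT assay, with a stated time of 48 h (a lower number here means a stronger inhibitor, a higher number a weaker inhibitor), the lowest of the two numbers recorded there. Compound 1 `CC(=O)O[C@]1(C)/C=C/C(=O)/C(CO)=C\C[C@](C)(CCC=C(C)C)/C=C/[C@H]1OC(=O)C=C(C)C` gives 3150 nM in this assay, a gap from compound 2 that lies beyond the scatter. Compound 3 `CC(C)=CCC[C@]1(C)/C=C/[C@@H](OC(=O)C=C(C)C)[C@](C)(O)CCC(=O)/C(CO)=C\C1` reaches only a limit of this assay, > 40000 nM, rather than a number. Compound 4 `CC(C)=CCC[C@]1(C)/C=C/[C@@H](OC(=O)C=C(C)C)[C@](C)(O)/C=C/C(=O)/C(Cn2cc(CO)nn2)=C\C1` carries one change relative to compound 2 (4-(hydroxymethyl)-1H-1,2,3-triazol-1-yl in place of chloro on a saturated chain carbon bound to a double-bonded ring carbon). Within the data shown here, no measured pair isolates such a swap, so the expectation rests on the spread already seen: compound 1 with its hydroxymethyl at 3150 nM sits well above compound 2. Compound 4 is therefore expected to be a weaker inhibitor, with a step of a 33-fold higher number from compound 2 to compound 4 (1.52 log units; beyond the scatter) in this assay. The estimated value of compound 4 is 5000 nM, with a likely range from 1000 nM to 25000 nM.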

Compound 4, half-maximal inhibitory concentration: 3470 nM
Beside the measured number, compound 4's estimate is 1.4-fold (0.16 log units) above it, within the range that was stated.
By their numbers in this assay, from the lowest: compound 2; then compounds 1 and 4 (each within the scatter of the next). At a limit, above all of these: compound 3.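

In this assay, 4-(hydroxymethyl)-1H-1,2,3-triazol-1-yl in place of chloro gives a 23-fold higher number from compound 2 to compound 4 (1.36 log units; beyond the scatter) as the first single change measured on this saturated chain carbon bound to a double-bonded ring carbon, so the chloro form holds a clear advantage over this group. Even so, compound 4 still gives a number rather than reaching a limit of the assay. Nothing measured here explains the loss.

On these data alone, what a bromo group, an amine or a triazole bearing a longer chain would give on this carbon stays open. So does how much of the step belongs to the triazole ring and how much to its hydroxymethyl.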